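A few compounds are considered here, and "the series" means these few. Any claim that something is new, unique, unknown or untested is made for them only; others in the source may bear on it.

Working notes on the series in an ADME assay on microsomes from liver (Homo sapiens) for metabolic stability; on this read-out lower numbers stand for slow clearance and higher numbers for fast clearance. Compound 1 `Cc1ccc2[nH]c(C(=O)N[C@H]3CN(S(=O)(=O)c4ccccc4)C[C@@H]3C(=O)N[C@@H]3CCCN(C)C3)cc2c1` gives 50 mL.min-1.g-1, and compound 2 `Cc1ccc2[nH]c(C(=O)N[C@H]3CN(S(=O)(=O)c4ccccc4)C[C@@H]3C(=O)N[C@@H]3CCCNC3)cc2c1` gives 3 mL.min-1.g-1. The step between them is a 17-fold lower number from compound 1 to compound 2 (1.22 log units; beyond the scatter), with hydrogen in place of methyl on the ring amine. Compound 3 `Cc1ccc2[nH]c(C(=O)N[C@H]3CN(S(=O)(=O)c4ccccc4)C[C@@H]3C(=O)N[C@H]3CCCNC3)cc2c1` gives < 3 mL.min-1.g-1, which is a limit and not a number. Its position therefore rests on (the limit of < 3 mL.min-1.g-1 in this assay, at which 1 of the 3 values shown sits). Against the methylated amine, the step is an at least 16-fold lower number from compound 1 to compound 3 (1.22 log units; beyond the scatter). Its relation to its partner is the fact that compounds 2 and 3 differ only in the configuration as drawn, and the step is a number no higher from compound 2 to compound 3 (the limit leaves the size open).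

Compound 4 `O=C(N[C@H]1CN(S(=O)(=O)c2ccccc2)C[C@@H]1C(=O)N[C@H]1CCCNC1)c1cc(-c2ccc(Cl)cc2)on1` keeps the amine and configuration of compound 3 and changes one group: 5-(4-chlorophenyl)-1,2-oxazol-3-yl in place of 5-methyl-1H-indol-2-yl on a carbonyl carbon. This places 5-(4-chlorophenyl)-1,2-oxazol-3-yl in place of 5-methyl-1H-indol-2-yl on a carbonyl carbon. Within the data shown here, no measured step touches this group, so the large steps bear on it only indirectly. With the unmethylated amine kept, a step of the size of a 17-fold lower number from compound 1 to compound 2 (1.22 log units; beyond the scatter) is not expected, and compound 2 at 3 mL.min-1.g-1 remains the nearest numerical guide. A small rise in this assay is expected, and the expected step is an at least 1.6-fold higher number from compound 3 to compound 4 (0.22 log units; that floor lies within the scatter). For compound 4 the estimated value is 5 mL.min-1.g-1, with an expected range of 2 mL.min-1.g-1 to 15 mL.min-1.g-1.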

Compound 4, intrinsic clearance in microsomes: < 3 mL.min-1.g-1
Compound 4: no number, only a limit; the forecaster's own chance of this, stated with the estimate: 35%; middle value at least 1.6-fold (0.22 log units) from the limit.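

Compound 3 and compound 4 both stand only as limits in this assay, and no step can be read between them. The compounds shown leave open the actual value of either compound, and whether 5-(4-chlorophenyl)-1,2-oxazol-3-yl in place of 5-methyl-1H-indol-2-yl on a carbonyl carbon changes this read-out at all.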